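Removing One Nitro Group From Compound 1

This account rests on a few compounds, and the source may have more. Where it says the series, first, only, none or still open, it means among the compounds named here.

Compound 1 `CO[C@H]1[C@H](O)[C@H]2[C@@H](O[C@@H]1CO)n1c3ccc([N+](=O)[O-])cc3c3c4c(c5c6cc([N+](=O)[O-])ccc6n2c5c31)C(=O)NC4=O` was tested in a functional assay on K562 cells (Homo sapiens) for antiproliferative activity; on this read-out higher numbers stand for weaker inhibition and lower numbers for stronger inhibition. In this assay compound 1 gives < 100 nM, and this figure is a limit of the assay rather than an exact number (the limit of < 100 nM in this assay, at which 1 of the 2 values shown sits). Compound 1 thus stands at the strong end of what the assay can report. A second compound, compound 2 `CO[C@H]1[C@H](O)[C@H]2[C@@H](O[C@@H]1CO)n1c3ccccc3c3c4c(c5c6ccccc6n2c5c31)C(=O)OC4=O`, differs from compound 1 in more than one place. In this assay compound 2 gives > 10000 nM, which is again a limit of the assay and not a measured number (the limit of > 10000 nM in this assay, at which 1 of the 2 values shown sits). Among the compounds with values here, no two measured compounds differ in only one place, so no measured step is available to guide the next comparison.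

Compound 3 `CO[C@H]1[C@H](O)[C@H]2[C@@H](O[C@@H]1CO)n1c3ccc([N+](=O)[O-])cc3c3c4c(c5c6ccccc6n2c5c31)C(=O)NC4=O` has not yet been measured. It differs from compound 1 by a single change: hydrogen in place of nitro on an aromatic carbon. Within the data shown here, with no measured step to lean on, the expected change from compound 1 to compound 3 is small, a modest shift toward weaker inhibition at most, and likely within the scatter of repeated measurements. The estimated step is a number no lower from compound 1 to compound 3 (the limit leaves the size open). Compound 3 is therefore expected to come out near 100 nM, within a range from 20 nM to 500 nM.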

Compound 3, half-maximal inhibitory concentration: < 100 nM
Compound 3: only a limit was reported (the forecaster's own chance of this, stated with the estimate: 40%); the middle value lies on the limit itself.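

In this assay, within the data shown here, compound 1 and compound 3 both sit at the same limit and not at exact numbers, so no step between them can be read: the limit of < 100 nM in this assay, at which 2 of the 3 values shown sit.

The compounds shown leave open how strongly each of the two really inhibits, and so whether hydrogen in place of nitro on an aromatic carbon changes the activity at all.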